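This account rests on a few compounds, and the source may have more. Where it says the series, first, only, none or still open, it means among the compounds named here.

Compound 1, `COc1ccc(Nc2nccc(-c3cn(C4CCCC4)c4ccccc34)n2)c(OC)c1`, is one of three compounds tested in a functional assay on MV4-11 cells (Homo sapiens) for inhibition, read by resazurin assay, with a stated time of 72 h; a lower number here means a stronger inhibitor of growth, a higher number a weaker inhibitor of growth. In this assay compound 1 gives 1740 nM, the highest number of the three, so it is the weakest grower inhibitor among them. Compound 3, `Oc1ccccc1Nc1nccc(-c2c[nH]c3ccccc23)n1`, is the nearest of the two others and gives 570 nM; the gap between compound 1 and compound 3 lies beyond the usual scatter. Furthest from compound 1 stands compound 2, `COc1ccc(Nc2nccc(-c3sc(SCc4cccnc4)nc3C)n2)c(OC)c1`, which gives 270 nM, again a gap beyond the scatter. Neither compound 2 nor compound 3 differs from compound 1 in only one place, so the numbers show where the three stand, but not what any single change does.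

Compound 4, `COc1ccc(Nc2nccc(-c3cn(C(C)C)c4ccccc34)n2)c(OC)c1`, differs from compound 1 in one place: isopropyl in place of cyclopentyl on an aromatic nitrogen. Among the measured compounds shown here, no measured pair shows what such a swap of one group for another on this ring nitrogen does to growth inhibition, so the size and direction of the step cannot be read from the data. The change is expected to move the number little, if at all, so the step of a 1.2-fold lower number from compound 1 to compound 4 (0.06 log units; within the scatter) is estimated to lie within the scatter. Compound 4 is therefore expected to give about 1500 nM, with a range from 600 nM to 4000 nM.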

Compound 4, concentration for 50% growth inhibition: 3250 nM
The estimate for compound 4 lay 2.2-fold (0.34 log units) below the measured number; low and high end bracket the measured number.
By their numbers in this assay, from the lowest: compound 2; then compound 3; then compounds 1 and 4 (each within the scatter of the next).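

In this assay, among the compounds shown here, the swap of cyclopentyl for isopropyl on the aromatic nitrogen gives the first step that can be read at this position: a 1.9-fold higher number from compound 1 to compound 4 (0.27 log units; within the scatter), so the two compounds cannot be told apart. This pair shows that the five-membered non-aromatic ring of carbon can give way to an open isopropyl group, with 3 heavy atoms in place of 5, without a step beyond the usual scatter, although one pair says nothing about other groups at this nitrogen or about this swap on other cores. No measurement at hand offers an explanation for this result.

As far as these compounds go, both groups here are plain carbon groups with no hydrogen-bond donors or acceptors, so it remains open whether a group of a different kind on this nitrogen, such as a chain ending in an amine or a carboxylic acid, would give a step beyond the scatter. From the compounds shown here alone, it also remains open how a longer carbon chain, or a simple hydrogen on this nitrogen with the rest of compound 1 kept unchanged, would compare.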